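A few compounds are considered here, and "the series" means these few. Any claim that something is new, unique, unknown or untested is made for them only; others in the source may bear on it.

Measured compounds:
compound 1 `C=C(Br)C(=O)Nc1cccc(-c2cn3nc(-c4ccc(OCC)cc4)sc3n2)c1`: 1100 nM
compound 2 `C=C(Br)C(=O)Nc1cccc(-c2cn3nc(-c4ccc(OC)cc4)sc3n2)c1`: 890 nM

In a functional assay on FM3A cells (Mus musculus) for inhibition, read by cell counting, with a stated time of 2 days (on this read-out higher numbers stand for weaker inhibition and lower numbers for stronger inhibition), compound 2 gives 890 nM, and compound 1 gives 1100 nM; the step of a 1.2-fold lower number from compound 1 to compound 2 (0.09 log units; within the scatter) keeps both within the usual scatter of each other. Compound 3 `C=C(Br)C(=O)Nc1cccc(-c2cn3nc(-c4ccc(Cl)cc4)sc3n2)c1` differs from compound 2 by chloro in place of methoxy on an aromatic carbon. For the measured compounds named here, the only measured step changes the saturated chain on the oxygen, not the oxygen itself, so no measured step covers this change. The expected step is a 1.0-fold higher number from compound 2 to compound 3 (0.00 log units; within the scatter). Compound 3 is therefore estimated at 900 nM, within 300 nM to 3000 nM.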

Compound 3, half-maximal inhibitory concentration: 2000 nM
Compound 3: middle estimate off by 2.2-fold (0.35 log units), on the low side; the measured number falls inside the stated range.
By their numbers in this assay, from the lowest: compounds 2, 1 and 3 (each within the scatter of the next, the first and the last beyond it).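

At this position, the earlier pair changed only the chain on the oxygen, while replacing the whole methoxy group with chloro gives a 2.2-fold higher number from compound 2 to compound 3 (0.35 log units; beyond the scatter) in this assay, a modest step and the first here beyond the scatter. Chloro in place of ethoxy gives a 1.8-fold higher number from compound 1 to compound 3 (0.26 log units; within the scatter), so this difference rests on one pair of compounds. Nothing available here explains either step. From the compounds shown here alone, how an amine, a carboxylic acid or a longer chain on the oxygen would read at this position remains open.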